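The source may hold more compounds than are shown below. What is called first, only, known or untested is meant among the compounds shown, and "the series" means these compounds.

Compound 3 `C=CCN(C)C(=O)c1ccc(C(CC)(CC)c2ccc(OCCC(O)(CC)CC)c(C)c2)n1CC` is the reference point here. In an ADME assay on L02 cells (Homo sapiens) for antiproliferative activity, read by MTT assay, with a stated time of 48 h (on this read-out lower numbers stand for stronger inhibition and higher numbers for weaker inhibition), compound 3 gives 1190 nM. Compound 1 `CCN(CC)CCNC(=O)c1ccc(C(CC)(CC)c2ccc(OCCC(O)(CC)CC)c(C)c2)n1CC` gives 2290 nM in this assay, and the step of a 1.9-fold lower number from compound 1 to compound 3 (0.28 log units; within the scatter) is within the scatter, so these two compounds are alike on this read-out. Compound 2 `CCn1c(C(=O)NCC#N)ccc1C(CC)(CC)c1ccc(OCCC(O)(CC)CC)c(C)c1` gives only a limit of the assay in this assay, > 50000 nM, and no number.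

Compound 4 `CCn1c(C(=O)N(C)CC(=O)O)ccc1C(CC)(CC)c1ccc(OCCC(O)(CC)CC)c(C)c1` differs from compound 3 in one place: carboxy in place of vinyl on a saturated chain carbon bound to an amide-type nitrogen. The measured step that comes nearest to this change is an at least 21-fold higher number from compound 1 to compound 2 (1.33 log units; beyond the scatter), where a small polar group was placed on the same saturated chain carbon bound to the amide-type nitrogen, and the related step of an at least 42-fold lower number from compound 2 to compound 3 (1.62 log units; beyond the scatter) points the same way. Both are large and both say that a small polar group at this place is linked to a much higher number.

Compound 4 is therefore expected to show a step of a 13-fold higher number from compound 3 to compound 4 (1.10 log units; beyond the scatter) in this assay. The estimate for compound 4 is 15000 nM, with a range from 4000 nM to 50000 nM.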

Compound 4, half-maximal inhibitory concentration: 2150 nM
The estimate for compound 4 lay 7.0-fold (0.84 log units) above the measured number; the measured number lies below the stated range.
By their numbers in this assay, from the lowest: compounds 3, 4 and 1 (each within the scatter of the next). At a limit, above all of these: compound 2.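

In this assay, the swap of vinyl for carboxy on the saturated chain carbon bound to an amide-type nitrogen gives a 1.8-fold higher number from compound 3 to compound 4 (0.26 log units; within the scatter), so a carboxy group at this place leaves the read-out unchanged, and the step of a 1.1-fold lower number from compound 1 to compound 4 (0.03 log units; within the scatter) puts this compound level with the diethylamino amide too. The large step of an at least 23-fold lower number from compound 2 to compound 4 (1.36 log units; beyond the scatter) then sets compound 2 apart, showing that its weak reading does not extend to every group at this place. Compound 2 gives only a limit of the assay, not a number: the limit of > 50000 nM in this assay, at which 1 of the 4 values shown sits.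

Still open, as far as these compounds go, is whether the nitrile or the amide hydrogen of compound 2 goes with that limit; the (cyanomethyl)(methyl)amino and (carboxymethyl)amino amides would separate the two. Also open, from the compounds shown here alone, is how a primary amine or a longer chain ending in a carboxylic acid would read here.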